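The compounds below may be only part of what the source reports. "The series", "measured", "known", "first", "only" and "open" are said of these compounds alone.

Compound 1 `CCOC(=O)C1=Cc2ccccc2OC1(OCc1cn(-c2ccccc2)nn1)C(F)(F)F` was tested in a functional assay on HeLa cells (Homo sapiens) for inhibition, read by MTT assay, with a stated time of 24 h; on this read-out lower numbers stand for stronger inhibition and higher numbers for weaker inhibition. In this assay compound 1 gives > 150000 nM, which is a limit of the assay rather than a number. Compound 3 `CCOC(=O)C1=Cc2ccccc2OC1(OCc1cn(-c2cccc(C(F)(F)F)c2)nn1)C(F)(F)F` carries a trifluoromethyl in place of a hydrogen on an aromatic carbon, and in this assay compound 3 also gives > 150000 nM, again a limit. The step that the two limits leave unreadable from compound 1 to compound 3 therefore cannot be read. Among the measured compounds shown here, compound 2 `CCOC(=O)C1=Cc2ccccc2OC1(OCc1cc(-c2ccc(Cl)cc2)no1)C(F)(F)F` stands apart: in this assay compound 2 gives 12300 nM, the only number among the three, the other two sitting at the limit of > 150000 nM in this assay, at which 2 of the 3 values shown sit.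

Compound 4 `CCOC(=O)C1=Cc2ccccc2OC1(OCc1cc(-c2ccc(F)cc2)no1)C(F)(F)F` differs from compound 2 by fluoro in place of chloro on an aromatic carbon, para to a large group. For the measured compounds named here, no measured step covers an exchange of one halogen for another, so the expectation rests on compound 2 alone. Compound 4 is expected to stay close to compound 2, with the step of a 1.5-fold higher number from compound 2 to compound 4 (0.17 log units; within the scatter) expected to lie within the usual scatter. The estimate for compound 4 is 18000 nM, with a range from 6000 nM to 60000 nM.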

Compound 4, half-maximal inhibitory concentration: 42300 nM
Estimate against measurement, compound 4: 2.4-fold (0.37 log units) below; the measured number falls inside the stated range.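

In this assay, this place on an aromatic carbon, para to a large group, proves sensitive to the choice of halogen: fluoro in place of chloro gives a 3.4-fold higher number from compound 2 to compound 4 (0.54 log units; beyond the scatter) and lies beyond the usual scatter. This is the first change among the compounds shown whose size can be read, since the earlier step, trifluoromethyl in place of hydrogen, has limits at both ends and cannot be read. Nothing shown bears on why the chloro compound gives the lower number.

From the compounds shown here alone, whether bromo, methoxy or an amine in this same place would give a lower or higher number than chloro and fluoro remains open. So does the effect on this read-out of replacing the ethyl ester of the shared core with a carboxylic acid or an amide.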